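The compounds below may be only part of what the source reports. "The series", "measured", "known", "first", "only" and "open" are said of these compounds alone.

Among the compounds with values here, compound 1 `CCCCCCCCCCCCNC(=O)[C@@H](NC(=O)c1cccs1)[C@@H](C)O` is the only compound of this pair with a number: in a functional assay on MCF7 cells (Homo sapiens) for cytotoxicity, read by MTT assay, with a stated time of 48 h (on this read-out higher numbers stand for weaker inhibition and lower numbers for stronger inhibition), compound 1 gives 30400 nM. Compound 2 `CCCCCCCCCCCCNC(=O)[C@@H](NC(=O)/C=C/c1ccccc1)[C@@H](C)O` reaches only a limit of this assay, > 200000 nM. The step of an at least 6.5-fold higher number from compound 1 to compound 2 (0.81 log units; beyond the scatter) is therefore known only as a floor on its size, because compound 2 sits at the limit of > 200000 nM in this assay, at which 1 of the 2 values shown sits. Compound 3 `C/C=C/C=C/C(=O)N[C@H](C(=O)NCCCCCCCCCCCC)[C@@H](C)O` differs from compound 2 by prop-1-en-1-yl in place of phenyl on a double-bonded chain carbon bound to a double-bonded chain carbon. Within the data shown here, only one measured step bears on this change, and it runs from a number into the limit, so it shows that compound 2 is weak but not how weak. Nothing measured here shows that going from 2-phenylethenyl to penta-1,3-dien-1-yl recovers potency, and compound 2 cannot be placed more exactly than its limit. The step of an at least 1.3-fold lower number from compound 2 to compound 3 (0.12 log units; that floor lies within the scatter) is therefore expected to be small and uncertain. Compound 3 is estimated at 150000 nM, in a range from 40000 nM to 400000 nM, with a fair chance that this assay again reports only a limit.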

Compound 3, half-maximal inhibitory concentration: 37100 nM
Compound 3: the middle estimate sits 4.0-fold (0.61 log units) above what was measured; the measured number lies below the stated range.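

In this assay, replacing phenyl with prop-1-en-1-yl on a double-bonded chain carbon bound to a double-bonded chain carbon gives an at least 5.3-fold lower number from compound 2 to compound 3 (0.73 log units; beyond the scatter), so the weak result of compound 2 does not extend to every unsaturated chain on this carbonyl carbon. This step is known only as a floor on its size, because compound 2 sits at a limit: the limit of > 200000 nM in this assay, at which 1 of the 3 values shown sits. Penta-1,3-dien-1-yl and thiophen-2-yl on the carbonyl carbon cannot be told apart, with a 1.2-fold higher number from compound 1 to compound 3 (0.09 log units; within the scatter), so a ring at this place is not required to reach this level of cytotoxicity.

Going by these compounds, the true value of compound 2 remains unknown, so the full size of the step to compound 3 stays open. The compounds shown also leave open whether a saturated pentyl chain or a chain ending in an amine would hold this level.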